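This account rests on a few compounds, and the source may have more. Where it says the series, first, only, none or still open, it means among the compounds named here.

Among the compounds with values here, in a functional assay on U-373MG ATCC cells (Homo sapiens) for inhibition, read by MTT assay, with a stated time of 72 h (a lower number here means a stronger inhibitor, a higher number a weaker inhibitor), compound 1 (`CC1(C)CC(NC(=S)Nc2cccc(C#N)c2)c2cc(Br)ccc2O1`) gives 6000 nM, the lower of the two numbers measured so far. Within the data shown here, compound 2 (`CC1(C)CC(NC(=S)Nc2cccc(C#N)c2)c2cc(F)ccc2O1`) gives 30000 nM and is the only measured neighbour of compound 1. Compound 3 (`CC1(C)CC(NC(=S)NCc2ccccc2)c2cc(Br)ccc2O1`) keeps the bromo substituent of compound 1 and differs from it in one place: benzyl in place of 3-cyanophenyl on an amide-type nitrogen.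

Among the measured compounds shown here, no measured step touches that place, since the 3-cyanophenyl group is the same in compound 1 and compound 2. For the measured compounds named here, the only step available is a 5.0-fold higher number from compound 1 to compound 2 (0.70 log units; beyond the scatter), with fluoro in place of bromo on an aromatic carbon. It bears on the question only as a gauge of how far one change has moved the number in this assay. A step of about that modest size is therefore expected, leaning towards a higher number, though the data do not fix the direction. The estimated step is a 1.7-fold higher number from compound 1 to compound 3 (0.22 log units; within the scatter). For compound 3 the expected value is 10000 nM, with an estimated range from 3000 nM to 35000 nM.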

Compound 3, half-maximal inhibitory concentration: 29000 nM
Beside the measured number, compound 3's estimate is 2.9-fold (0.46 log units) below it; low and high end bracket the measured number.
By their numbers in this assay, from the lowest: compound 1; then compounds 3 and 2 (each within the scatter of the next).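

Within the data shown here, the amide-type nitrogen proves sensitive in this assay: with benzyl in place of 3-cyanophenyl there is a 4.8-fold higher number from compound 1 to compound 3 (0.68 log units; beyond the scatter), the first measured change at this place. This step is modest and beyond the scatter, as is a 5.0-fold higher number from compound 1 to compound 2 (0.70 log units; beyond the scatter), so a single change at either the aromatic carbon bearing the bromo group or the amide-type nitrogen takes the number away from that of compound 1, which stays the lowest of the three. No measurement shown here explains why the number rises with this change.

The change from 3-cyanophenyl to benzyl removes the nitrile and also replaces the phenyl group with a benzyl group, and the compounds shown leave open which of these accounts for the step. An unsubstituted phenyl group on this nitrogen would begin to separate the two, while a 2-phenylethyl chain, or a 3-carboxyphenyl or 3-aminophenyl group in place of 3-cyanophenyl, would show how far the number follows the length of the chain or the group carried on the ring.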